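This account rests on a few compounds, and the source may have more. Where it says the series, first, only, none or still open, it means among the compounds named here.

Measured so far in a functional assay on HL-60 cells (Homo sapiens) for cytotoxicity, read by WST assay, with a stated time of 48 h; a lower number here means that less compound is needed, a higher number that more compound is needed for the effect:
- compound 1 `O=C1OC[C@H](Cc2ccccc2)[C@H]1Cc1ccc(OC(F)(F)F)cc1`: 27000 nM
- compound 2 `COc1ccccc1C[C@H]1COC[C@@H]1Cc1ccc(Cl)c(Cl)c1`: 55000 nM

Compound 2 has the higher number of the pair, at 55000 nM, so more of it is needed for the effect. Its nearest neighbour is compound 1, and the gap between them lies beyond the scatter. Going by the values given here, these compounds differ in more than one place, so no single-change step is available to show how large a change of this kind might be.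

Compound 3 `Fc1ccccc1C[C@H]1COC[C@@H]1Cc1ccc(Cl)c(Cl)c1` departs from compound 2 in one place: fluoro in place of methoxy on an aromatic carbon. This puts fluoro in place of methoxy on an aromatic carbon of a six-membered aromatic ring of carbon only, ortho to a large group.

Among the compounds with values here, with no measured precedent for this exchange, no step beyond the scatter is expected in this assay, and neither direction is favoured. The expected change is a 1.2-fold lower number from compound 2 to compound 3 (0.09 log units; within the scatter). The estimate for compound 3 is 45000 nM, with an expected range of 20000 nM to 100000 nM.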

Compound 3, half-maximal effective concentration: 51000 nM
Beside the measured number, compound 3's estimate is 1.1-fold (0.05 log units) below it; low and high end bracket the measured number.
By their numbers in this assay, from the lowest: compounds 1, 3 and 2 (each within the scatter of the next, the first and the last beyond it).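

In this assay, fluoro in place of methoxy on an aromatic carbon, ortho to a large group, gives a 1.1-fold lower number from compound 2 to compound 3 (0.03 log units; within the scatter), the first single-change step available in this series. At this position, methoxy with its 2 heavy atoms and 1 hydrogen-bond acceptor and fluoro with 1 heavy atom and 0 hydrogen-bond acceptors cannot be told apart by this read-out, so this pair offers no sign that the exchange matters for the number. This holds for this one pair on the shared core only, and no measurement at hand accounts for the result.

On these data alone, whether the same position is equally indifferent to an amine, a carboxylic acid or a longer chain such as butoxy stays open, as does whether this exchange would give a similar step on another aromatic carbon of the series. Compound 1 differs from compound 2 and compound 3 in more than one place, so the shared core still lacks a single-change step that lies beyond the scatter.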